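The compounds below may be only part of what the source reports. "The series", "measured", "known", "first", "only" and "open" are said of these compounds alone.

Compound 1 `COc1cc(NC(C)CCCNC(=O)/C=C/c2cccc(C(F)(F)F)c2)c2ncccc2c1` and compound 2 `COc1cc(NC(C)CCCNC(=O)/C=C/c2ccc(C(F)(F)F)cc2)c2ncccc2c1` share one core and differ in a single place: 4-(trifluoromethyl)phenyl in place of 3-(trifluoromethyl)phenyl on a double-bonded chain carbon bound to a double-bonded chain carbon. In an ADME assay on L6 cells (Rattus norvegicus) for cytotoxicity, read by resazurin assay, with a stated time of 70 h (on this read-out higher numbers stand for weaker inhibition and lower numbers for stronger inhibition), compound 1 gives 16200 nM, whereas compound 2 gives 160000 nM; the change produced a 9.9-fold higher number from compound 1 to compound 2 (0.99 log units; beyond the scatter). Compound 3 `COc1cc(NC(C)CCCNC(=O)NNC(=O)/C=C/c2cccc(C(F)(F)F)c2)c2ncccc2c1` is built on a different core, and the difference between the two cores is not broken down here. In this assay compound 3 gives 10600 nM. Compound 4 `COc1cc(NC(C)CCCNC(=O)NNC(=O)/C=C/c2ccc(C(F)(F)F)cc2)c2ncccc2c1` stands to compound 3 exactly as compound 2 stands to compound 1: 4-(trifluoromethyl)phenyl in place of 3-(trifluoromethyl)phenyl on a double-bonded chain carbon bound to a double-bonded chain carbon. The two places read the same word for word, so this is the same kind of change carried onto the core of compound 3. A step of similar size is expected for compound 4, a 9.4-fold higher number from compound 3 to compound 4 (0.97 log units; beyond the scatter), because the same change on the first core gave a 9.9-fold higher number from compound 1 to compound 2 (0.99 log units; beyond the scatter). Compound 4 is accordingly estimated at 100000 nM, with a likely range from 30000 nM to 300000 nM.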

Compound 4, half-maximal inhibitory concentration: 28300 nM
The estimate for compound 4 lay 3.5-fold (0.55 log units) above the measured number; measured number below the stated range.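

Putting 4-(trifluoromethyl)phenyl in place of 3-(trifluoromethyl)phenyl in this assay gave a 2.7-fold higher number from compound 3 to compound 4 (0.43 log units; beyond the scatter) on the second core. The direction of the step therefore held on both cores, but its size did not carry over from one to the other: the same change on two cores in this assay, a 9.9-fold higher number (0.99 log units; beyond the scatter) from compound 1 to compound 2 and a 2.7-fold higher number (0.43 log units; beyond the scatter) from compound 3 to compound 4, 3.7-fold (0.57 log units) apart, beyond the scatter of two such steps. These two pairs show that a step measured on one core did not fix the size of the same step on the other, but they do not show which part of the cores sets that size or how the change would behave on any further core.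

Going by these compounds, it remains open whether a nitrile in place of trifluoromethyl would follow the same course on these two cores. The same question stands for a saturated ethyl link in place of the ethenyl.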